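Substituent exchange on the fused ring and maximal response

The source may report more compounds than this note shows. Statements on the series, on what has been measured and on what is new or still open speak of the compounds shown alone.

Compound 1 `CC#C[C@@H](CC(=O)O)c1ccc(OC[C@H]2COc3ccc(OC(F)(F)F)cc3O2)cc1` and compound 2 `CC#C[C@@H](CC(=O)O)c1ccc(OC[C@H]2COc3ccc(S(C)(=O)=O)cc3O2)cc1` share one core and differ only in the group on an aromatic carbon of the fused ring. Going by the values given here, in a functional assay on HEK293 cells for agonist activity at Free fatty acid receptor 1 (Homo sapiens), read by fluorescence and calcium flux, with a stated time of 10 min (a higher number here means a larger maximal response, a lower number a smaller maximal response), compound 1 gives 73%, and compound 2 gives 55%, the lower of the two numbers measured so far. Among the compounds with values here, the single measured step, a number 18 percentage points lower from compound 1 to compound 2 (beyond the scatter), accompanied the exchange of trifluoromethoxy for methylsulfonyl. Compound 3 `CC#C[C@@H](CC(=O)O)c1ccc(OC[C@H]2COc3ccc(CO)cc3O2)cc1` carries a further exchange at the same carbon: hydroxymethyl in place of methylsulfonyl on an aromatic carbon. Within the data shown here, no measured step involves hydroxymethyl, so the step from compound 1 to compound 2 bears on it only by showing that swapping the group at this carbon shifted the maximal response modestly. For compound 3 the expected step is a number 5 percentage points higher from compound 2 to compound 3 (within the scatter), with no direction favoured beyond the scatter. The estimate for compound 3 in this assay is 60%, between 40% and 80%.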

Compound 3, largest response reached (Emax), in percent of the reference or control that the assay uses: 42%
Compound 3: middle estimate off by 18 percentage points, on the high side, and the stated range covers the measured number.
By their numbers in this assay, from the lowest: compound 3; then compound 2; then compound 1.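

In this assay, the position proves more sensitive than the first exchange alone suggested: hydroxymethyl in place of methylsulfonyl gives a number 13 percentage points lower from compound 2 to compound 3 (beyond the scatter), and hydroxymethyl in place of trifluoromethoxy gives a number 31 percentage points lower from compound 1 to compound 3 (beyond the scatter). All three groups at this aromatic carbon now stand apart beyond the scatter, with compound 3 the lowest of the set, so the maximal response here follows the identity of the group and the second step is not a repeat of scatter. Nothing at hand accounts for the fall in response with either exchange.

Open, on these data alone, is whether the drop belongs to the free hydroxyl of hydroxymethyl or to the group as a whole, which a methoxymethyl or aminomethyl group at the same carbon would help separate. Also open, as far as these compounds go, is how a carboxylic acid or a longer chain at this carbon would compare with these three groups.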